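This account rests on a few compounds, and the source may have more. Where it says the series, first, only, none or still open, it means among the compounds named here.

Measured compounds:
compound 1 `N[C@@H](COP(=O)(O)OCCCOC(=O)CCc1ccccc1OCc1cccc(Oc2ccc(Cl)c(Cl)c2)c1)C(=O)O` — in an assay on cells for activation of probable G-protein coupled receptor 34 (Mus musculus), with a stated time of 1 h (a higher number here means a larger maximal response, a lower number a smaller maximal response), compound 1 gives 0.71
compound 2 `CC(C)(C)c1cccc(Oc2cccc(COc3ccccc3CCC(=O)OCCCOP(=O)(O)OC[C@H](N)C(=O)O)c2)c1` — in this assay compound 2 gives 0.39

For the measured compounds named here, compound 2 stands lowest of the two numbers in this assay; the single measured step, a number 0.32 lower from compound 1 to compound 2 (beyond the scatter), lies beyond the scatter and is large. Compound 3 `CC(C)(C)c1ccc(Oc2cccc(COc3ccccc3CCC(=O)OCCCOP(=O)(O)OC[C@H](N)C(=O)O)c2)cc1` is not yet measured. Its difference from compound 2 is 4-(tert-butyl)phenyl in place of 3-(tert-butyl)phenyl on an oxygen on an aromatic ring. Going by the values given here, no measured step bears directly on this change: the step from compound 1 to compound 2 exchanges one phenyl for another, whereas here the same atoms are joined differently, 4-(tert-butyl)phenyl in place of 3-(tert-butyl)phenyl on an oxygen on an aromatic ring. With no anchor for the direction, the expected step is modest, a number 0.060 higher from compound 2 to compound 3 (within the scatter), and may well fall within the scatter. Compound 3 is therefore estimated at 0.45, with a range from 0.25 to 0.7.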

Compound 3, intrinsic activity: the largest response reached, as a fraction of the reference agonist's: 0.079
Beside the measured number, compound 3's estimate is 0.37 above it; measured number below the stated range.
By their numbers in this assay, from the lowest: compound 3; then compound 2; then compound 1.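

The same atoms, joined differently, give a large change in this assay: a number 0.31 lower from compound 2 to compound 3 (beyond the scatter) with 4-(tert-butyl)phenyl in place of 3-(tert-butyl)phenyl on an oxygen on an aromatic ring. The earlier pair changed the substituents themselves, while this pair shows that where the tert-butyl group stands on that phenyl also counts. Taken against the 3,4-dichlorophenyl compound, the same 4-(tert-butyl)phenyl group gives a number 0.63 lower from compound 1 to compound 3 (beyond the scatter) and the largest step in the series so far. Nothing shown gives a reason for this dependence on placement.

As far as these compounds go, whether the change follows the tert-butyl group or any substituent placed this way remains open. Unsubstituted phenyl, 3-chlorophenyl and 4-chlorophenyl on the same oxygen would separate these two readings.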